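This account rests on a few compounds, and the source may have more. Where it says the series, first, only, none or still open, it means among the compounds named here.

Compound 1 `CCOC(=O)Nc1cccc2c1CN(C)CC2c1ccccc1`: about 4 mg/kg
Compound 2 `CCNCCC(=O)Nc1cccc2c1CN(C)CC2c1ccccc1`: > 160 mg/kg (a limit)
Compound 3 `CCCCNCCC(=O)Nc1cccc2c1CN(C)CC2c1ccccc1`: not yet measured

In a functional assay on the whole organism for inhibition, with Mus musculus as the target (on this read-out higher numbers stand for an effect only at larger amounts of compound and lower numbers for an effect already at smaller amounts), compound 1 gives about 4 mg/kg as a number. Compound 2 stands at the limit of > 160 mg/kg in this assay, at which 1 of the 2 values shown sits, and so has a limit and not a number.

Compound 3 carries ethyl in place of hydrogen on a saturated chain carbon, two bonds along the chain from an amine nitrogen, which turns ethylamino into butylamino.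

For the measured compounds named here, only one measured step bears on this, and only indirectly. It is an at least 40-fold higher number from compound 1 to compound 2 (1.60 log units; beyond the scatter) for 2-(ethylamino)ethyl in place of ethoxy on a carbonyl carbon, a large step at the same carbonyl but of a different kind. Going by the values given here, no measured pair shows what lengthening the chain on the amine does. Compound 3 keeps the amine side chain, so a return towards compound 1 is not expected.

The expected outcome is a number no higher from compound 2 to compound 3 (the limit leaves the size open) in this assay, meaning no step beyond the scatter, and another limit is quite likely. Compound 3 is estimated at 160 mg/kg (expected range 60 mg/kg to 320 mg/kg).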

Compound 3, dose for half-maximal effect: 74 mg/kg
Estimate against measurement, compound 3: 2.2-fold (0.33 log units) above; the measured number falls inside the stated range.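

In this assay, the amine side chain is not a uniform dead end: butylamino in place of ethylamino gives an at least 2.1-fold lower number from compound 2 to compound 3 (0.33 log units; beyond the scatter), so a change on a saturated chain carbon, two bonds along the chain from an amine nitrogen, does register in this read-out. Compound 2 has only a limit and not a number, so the full size of this step cannot be read: the limit of > 160 mg/kg in this assay, at which 1 of the 3 values shown sits. Against ethoxy on the carbonyl carbon, 2-(butylamino)ethyl still gives a 19-fold higher number from compound 1 to compound 3 (1.27 log units; beyond the scatter), so the butyl chain closes only part of the gap to compound 1, and compound 3 stands between compound 1 and the limit of compound 2.

From the compounds shown here alone, whether a longer chain such as hexylamino would lower the number further, or whether the gain stops at butylamino, remains open, since two amines define no trend in chain length. Also open, going by these compounds, is how a cyclic amine such as piperidine, or a dimethylamino group at the end of the same side chain, would compare with compound 3.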